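Swapping Phenyl for Pyridin-2-yl on Compound 3

The compounds below may be only part of what the source reports. "The series", "measured", "known", "first", "only" and "open" are said of these compounds alone.

Of the compounds shown here, three built on a shared core have been measured so far: compound 1 (`Oc1cccc(-c2cc(-c3ccccc3)cc(-c3ccco3)n2)c1`), compound 2 (`Oc1cccc(-c2cc(-c3ccccc3)cc(-c3cccc(O)c3)n2)c1`) and compound 3 (`Oc1cccc(-c2cc(-c3ccccc3)nc(-c3ccccc3)c2)c1`). In a functional assay on HeLa cells (Homo sapiens) for cytotoxicity, read by ELISA, with a stated time of 2 days (on this read-out higher numbers stand for weaker inhibition and lower numbers for stronger inhibition), compound 1 gives 9430 nM, compound 2 gives 13000 nM and compound 3 gives 15100 nM. Compound 3 therefore stands within the scatter of both others, and the three numbers cannot be put in a firm order.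

The next compound, compound 4 (`Oc1cccc(-c2cc(-c3ccccc3)nc(-c3ccccn3)c2)c1`), has pyridin-2-yl in place of phenyl on an aromatic carbon, next to the ring nitrogen: pyridin-2-yl in place of phenyl on an aromatic carbon. Within the data shown here, no measured compound shows this exchange directly. The closest evidence is a different swap of one aromatic group for another, a 1.4-fold higher number from compound 1 to compound 2 (0.14 log units; within the scatter). That step is small and is the only one available, so it offers weak guidance, but it gives no reason to expect a large shift in this assay. The expected change is a 1.3-fold lower number from compound 3 to compound 4 (0.10 log units; within the scatter), which means no expected step beyond the scatter and no firm direction. For compound 4 the estimated value is 12000 nM, with an expected range from 5500 nM to 25000 nM.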

Compound 4, half-maximal inhibitory concentration: 29800 nM
The estimate for compound 4 lay 2.5-fold (0.40 log units) below the measured number, and the stated range ends below it.
By their numbers in this assay, from the lowest: compounds 1, 2, 3 and 4 (each within the scatter of the next, the first and the last beyond it).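

In this assay, among these compounds, the exchange of phenyl for pyridin-2-yl on the aromatic carbon next to the ring nitrogen gives a 2.0-fold higher number from compound 3 to compound 4 (0.30 log units; within the scatter), and this is the first direct reading of this change at this position. The entering group carries a hydrogen-bond acceptor that phenyl lacks, yet the step stays within the usual scatter, so this single pair does not establish that the exchange shifts the read-out at this position in either direction. No measurement bears on what lies behind this step, so the pair gives the size of the step and nothing about its origin.

The compounds shown leave open whether a group of a different kind at this position, such as an amine, a carboxylic acid or a longer alkyl chain, would give a step beyond the scatter. They also leave open how pyridin-3-yl or pyridin-4-yl would read here, and whether the same exchange on the phenyl group that remains in compound 4 would give a similar step.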